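The source may report more compounds than this note shows. Statements on the series, on what has been measured and on what is new or still open speak of the compounds shown alone.

Measured in a functional assay on cells for positive allosteric modulation of G-protein coupled receptor 68 (Homo sapiens), read by a luciferase reporter and cAMP accumulation, with a stated time of 30 min, at pH 6.8 and pH 8.3, in the presence of a further agent that is not named here; a higher number here means a more potent compound, by a factor of ten per unit of this negative logarithm, a lower number a less potent compound:
compound 1 `Nc1nc(NCc2ccccc2)nc(-c2ccccc2CO)n1`: 4.35
compound 2 `COc1ccc(CO)c(-c2nc(N)nc(NCc3ccccc3)n2)c1`: 3.99

Compound 1 stands highest of the two numbers, with compound 2 below it by a number 0.36 log units lower from compound 1 to compound 2 (beyond the scatter). Compound 3 `COc1cccc(CNc2nc(N)nc(-c3ccccc3CO)n2)c1` is not yet measured; from compound 1 it differs by methoxy in place of hydrogen on an aromatic carbon. Among the measured compounds shown here, the one measured step of the same kind, a number 0.36 log units lower from compound 1 to compound 2 (beyond the scatter), is the same change though not made at the same place, so it bears only loosely here; it was a modest loss beyond the scatter. A comparable or smaller loss is expected in this assay, as a number 0.25 log units lower from compound 1 to compound 3 (within the scatter). Compound 3 is therefore estimated at 4.1, within 3.7 to 4.5.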

Compound 3, negative logarithm of the antagonist equilibrium constant: 4.11
For compound 3 the middle estimate is 0.01 log units below the measured one; measured number inside the range.
By their numbers in this assay, from the lowest: compounds 2, 3 and 1 (each within the scatter of the next, the first and the last beyond it).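

The change from phenyl to 3-methoxyphenyl in this assay gives a number 0.24 log units lower from compound 1 to compound 3 (within the scatter) and shows that methoxy on this ring, meta to a large group, leaves the number within the scatter of compound 1. The same replacement at its other place gave a number 0.36 log units lower from compound 1 to compound 2 (beyond the scatter) and lay beyond the scatter, so the outcome of this change depends on where it is made in these compounds. No measurement at hand accounts for this difference. Open, as far as these compounds go, is whether a larger ether such as benzyloxy, an amine or a carboxylic acid at this place would move the number beyond the scatter. A single substituent at one ring position also says nothing about the other positions on that ring.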